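Weighing a methyl for a methoxy on the shared core

A few compounds are considered here, and "the series" means these few. Any claim that something is new, unique, unknown or untested is made for them only; others in the source may bear on it.

Measured compounds:
- Compound 1, `C=CCn1c(=O)/c(=C\c2ccc(Cl)c(Cl)c2)[nH]c(=O)/c1=C\c1ccccc1OC`: "not active" (no number reported)
- Compound 2, `C=CCn1c(=O)/c(=C\c2ccccc2OC)[nH]c(=O)/c1=C\c1ccccc1OC`: 7400 nM
- Compound 3, `COc1ccccc1/C=c1/[nH]c(=O)/c(=C\c2ccccc2OC)[nH]c1=O`: "not active" (no number reported)

In a functional assay on K562 cells (Homo sapiens) for cytotoxicity, read by CCK-8 assay, with a stated time of 72 h (a higher number here means a weaker inhibitor, a lower number a stronger inhibitor), compound 2 gives 7400 nM, and it is the only one of the three with a reported number. Compound 1 was reported as "not active" (no number reported) with no figure attached, and compound 3 was likewise reported as "not active" (no number reported) without a figure. Within the data shown here, compound 2 therefore stands alone as the single measured value, and no step between measured compounds can be drawn from these entries.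

Compound 4, `C=CCn1c(=O)/c(=C\c2cccc(C)c2)[nH]c(=O)/c1=C\c1ccccc1OC`, has not yet been measured in this assay. It differs from compound 2 in one place: 3-methylphenyl in place of 2-methoxyphenyl on a double-bonded chain carbon bound to an aromatic carbon. Among the measured compounds shown here, since no comparable step has been measured, the direction of the change is open. Compound 1, which also swaps out one of the two 2-methoxyphenyl groups of compound 2, gave no number, which suggests that losing that group may cost potency. Compound 4 is accordingly expected to be somewhat weaker than compound 2, with an estimated step of a 2.0-fold higher number from compound 2 to compound 4 (0.31 log units; beyond the scatter). Compound 4 is estimated at 15000 nM in this assay, within a range of 4000 nM to 60000 nM.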

Compound 4, half-maximal inhibitory concentration: 8800 nM
Compound 4: middle estimate off by 1.7-fold (0.23 log units), on the high side; measured number inside the range.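

In this assay, placing 3-methylphenyl in this position instead of 2-methoxyphenyl gives a 1.2-fold higher number from compound 2 to compound 4 (0.08 log units; within the scatter), so the two compounds cannot be told apart in this assay, even though the change removes the one hydrogen-bond acceptor counted in the leaving group. Among these compounds, this shows that 2-methoxyphenyl is not required at this place for a reported number, something that could not be seen while the only other change here was the one in compound 1, which gives "not active" (no number reported). Nothing available explains why compound 4 keeps a number while compound 1 has none.

On these data alone, whether an amine or a carboxylic acid on the phenyl ring at this place, or a longer chain in place of the methyl of 3-methylphenyl, would move the number beyond the scatter remains open. The compounds shown also leave open whether the same change to the other 2-methoxyphenyl group of compound 2 would be matched by a similar result.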